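Compound 3 to compound 4: changing the nitrogen substituent

This account rests on a few compounds, and the source may have more. Where it says the series, first, only, none or still open, it means among the compounds named here.

Values in a functional assay on HOS-TE85 cells (Homo sapiens) for inhibition, read by CCK-8 assay, with a stated time of 72 h (on this read-out lower numbers stand for stronger inhibition and higher numbers for weaker inhibition), so far
- compound 1 `CCN(CC)c1ccc(N2C(=O)CSC2c2cccc(C(=O)NCCCCc3ccccc3)c2)cc1` gives > 1000 nM (a limit)
- compound 2 `Cc1cccc(N2C(=O)CSC2c2cccc(C(=O)NCCCCc3ccccc3)c2)c1` gives 93.2 nM (a number)
- compound 3 `O=C(NCCCCc1ccccc1)c1cccc(C2SCC(=O)N2c2ccccc2F)c1` gives 34.1 nM (a number)

Compound 3 stands lowest of the two exact numbers, with the nearest gap being a 2.7-fold lower number from compound 2 to compound 3 (0.44 log units; beyond the scatter) (a modest step). Compound 4 `COc1ccc(N2C(=O)CSC2c2cccc(C(=O)NCCCCc3ccccc3)c2)c(OC)c1` carries a new group at the same place, the change being 2,4-dimethoxyphenyl in place of 2-fluorophenyl on an amide-type nitrogen in a ring (the only difference). All measured steps lie at this position. Leaving the 4-(diethylamino)phenyl gave an at least 10-fold lower number from compound 1 to compound 2 (1.03 log units; beyond the scatter) (large) and an at least 29-fold lower number from compound 1 to compound 3 (1.46 log units; beyond the scatter) (large), so this position can move the number strongly. Among the measured compounds shown here, no measured compound carries a 2,4-dimethoxyphenyl, which leaves the size of the step uncertain. Starting from the lowest number so far, a rise is expected, of a size at or beyond the modest step between compound 2 and compound 3. The expected step is a 4.4-fold higher number from compound 3 to compound 4 (0.64 log units; beyond the scatter) (toward weaker inhibition). For compound 4 the estimated value is 150 nM (expected range 40 nM to 600 nM) in this assay (to be tested).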

Compound 4, half-maximal inhibitory concentration: 90.4 nM
Compound 4: middle estimate off by 1.7-fold (0.22 log units), on the high side; measured number inside the range.
By their numbers in this assay, from the lowest: compound 3; then compounds 4 and 2 (each within the scatter of the next). At a limit, above all of these: compound 1.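

In this assay, adding a second substituent with oxygen to the ring on the amide-type nitrogen does not match the 2-fluorophenyl, at a 2.7-fold higher number from compound 3 to compound 4 (0.42 log units; beyond the scatter), while 2,4-dimethoxyphenyl and 3-methylphenyl cannot be told apart, at a 1.0-fold lower number from compound 2 to compound 4 (0.01 log units; within the scatter). The collapse seen with 4-(diethylamino)phenyl therefore does not extend to 2,4-dimethoxyphenyl, at an at least 11-fold lower number from compound 1 to compound 4 (1.04 log units; beyond the scatter). The size of that last step stays open-ended, since compound 1 is held at a limit and not a number: the limit of > 1000 nM in this assay, at which 1 of the 4 values shown sits.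

Still open, from the compounds shown here alone, is whether the loss in compound 1 belongs to the diethylamino group specifically or would also appear with a smaller amine such as a plain amino group. The compounds shown also leave open how unsubstituted phenyl or a single methoxy group would compare with the 2-fluorophenyl of compound 3.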